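From Methoxy to Methylsulfonyl on the Shared Core

This account rests on a few compounds, and the source may have more. Where it says the series, first, only, none or still open, it means among the compounds named here.

Compounds measured in an ADME assay on L6 cells (Rattus norvegicus) for cytotoxicity, read by fluorescence and resazurin assay, with a stated time of 72 h; a lower number here means that less compound is tolerated, a higher number that more compound is tolerated:
- compound 1 `Cc1ccc(-c2c[nH]cc2C(c2ccc(Cl)cc2Cl)n2ccnc2)cc1`: 18400 nM
- compound 2 `CCc1ccc(-c2c[nH]cc2C(c2ccc(Cl)cc2Cl)n2ccnc2)cc1`: 13400 nM
- compound 3 `COc1ccc(-c2c[nH]cc2C(c2ccc(Cl)cc2Cl)n2ccnc2)cc1`: 14800 nM

The value of compound 3 lies within the scatter of both other compounds, so the three cannot be told apart in this assay. Compound 4 `CS(=O)(=O)c1ccc(-c2c[nH]cc2C(c2ccc(Cl)cc2Cl)n2ccnc2)cc1` has methylsulfonyl in place of methoxy on an aromatic carbon, para to a large group (methylsulfonyl in place of methoxy on an aromatic carbon).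

Going by the values given here, three measured steps bear on this change. Methoxy in place of methyl showed a 1.2-fold lower number from compound 1 to compound 3 (0.09 log units; within the scatter), and methoxy in place of ethyl showed a 1.1-fold higher number from compound 2 to compound 3 (0.04 log units; within the scatter). Methyl in place of hydrogen on a saturated chain carbon showed a 1.4-fold lower number from compound 1 to compound 2 (0.14 log units; within the scatter). None of these steps involves methylsulfonyl, so they offer only indirect guidance. No step beyond the scatter is expected in either direction, although the uncertainty is wide. The expected step is a 1.1-fold higher number from compound 3 to compound 4 (0.03 log units; within the scatter). For compound 4 the estimated value is 16000 nM, within an expected range of 7000 nM to 40000 nM.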

Compound 4, half-maximal cytotoxic concentration: 68000 nM
Compound 4: the middle estimate sits 4.3-fold (0.63 log units) below what was measured, outside the stated range (above it).
By their numbers in this assay, from the lowest: compounds 2, 3 and 1 (each within the scatter of the next); then compound 4.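

In this assay, the place on the six-membered aromatic ring, where methyl, ethyl and methoxy could not be told apart, now proves responsive to the group it carries: methylsulfonyl in place of methoxy gives the largest-scale contrast seen so far (a 4.6-fold higher number from compound 3 to compound 4 (0.66 log units; beyond the scatter)), and the same holds against ethyl (a 5.1-fold higher number from compound 2 to compound 4 (0.71 log units; beyond the scatter)) and against methyl (a 3.7-fold higher number from compound 1 to compound 4 (0.57 log units; beyond the scatter)). Compound 4 therefore stands apart from all three earlier compounds, with more compound tolerated in each comparison. Nothing available accounts for why methylsulfonyl differs from the other groups.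

The compounds shown leave open whether this separation is particular to methylsulfonyl or would also appear with a sulfonamide, a carboxylic acid or an amine at this place. They also leave open whether a longer chain on the sulfonyl group would keep it.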